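Alkylamino–alkylthio series: chain extension on the amine

A few compounds are considered here, and "the series" means these few. Any claim that something is new, unique, unknown or untested is made for them only; others in the source may bear on it.

Measured compounds:
compound 1 `CCCCCCNc1nc(SC(C)C)nc2ncccc12` gives 20200 nM
compound 2 `CCCCNc1nc(SCCCC)nc2ncccc12` gives 13600 nM

In a functional assay on HT-29 cells (Homo sapiens) for cytotoxicity, read by neutral red uptake, with a stated time of 72 h (a higher number here means a weaker inhibitor, a lower number a stronger inhibitor), compound 2 holds the lower of the two numbers, with compound 1 the nearer neighbour by a gap that sits within the scatter, so no order between them is claimed. Compound 3 `CCCCCCNc1nc(SCCCC)nc2ncccc12` differs from compound 2 by ethyl in place of hydrogen on a saturated chain carbon, four bonds along the chain from a nitrogen on an aromatic ring. Among the compounds with values here, no step between measured compounds isolates this change. Compound 3 is expected to land close to compound 2, with the step of a 1.1-fold lower number from compound 2 to compound 3 (0.05 log units; within the scatter) estimated as none beyond the scatter. For compound 3 the estimate is 12000 nM, ranging from 5000 nM to 30000 nM.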

Compound 3, half-maximal inhibitory concentration: 2800 nM
The estimate for compound 3 lay 4.3-fold (0.63 log units) above the measured number; the whole stated range lies above it.
By their numbers in this assay, from the lowest: compound 3; then compounds 2 and 1 (each within the scatter of the next).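

In this assay, ethyl in place of hydrogen on a saturated chain carbon, four bonds along the chain from a nitrogen on an aromatic ring, gives a 4.9-fold lower number from compound 2 to compound 3 (0.69 log units; beyond the scatter), so this chain position responds beyond the scatter. Butyl in place of isopropyl on a sulfur gives a 7.2-fold lower number from compound 1 to compound 3 (0.86 log units; beyond the scatter), so the sulfur substituent also matters when the amine chain is held constant. No evidence here bears on the reason for either step.

Going by these compounds, whether an octyl chain on the amine would extend this gain remains open. On these data alone, the sulfur step is read only with hexyl on the amine, so its size with butyl there is also open.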